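The source may hold more compounds than are shown below. What is called first, only, known or untested is meant among the compounds shown, and "the series" means these compounds.

Going by the values given here, compound 3 `CC1CCN(C2CCN(S(=O)(=O)c3cccc(-c4ccc5ccccc5c4)c3)CC2)CC1` gives 2 nM in a functional assay on DLD-1 cells (Homo sapiens) for antiproliferative activity, read by CellTiter-Glo, with a stated time of 72 h (on this read-out lower numbers stand for stronger inhibition and higher numbers for weaker inhibition), the lowest of the three numbers so far, although compound 2 `CC1CCN(C2CCN(S(=O)(=O)c3ccc(Cl)c(Cl)c3)CC2)CC1` gives 2.9 nM, within the scatter of it, while compound 1 `CC1CCN(C2CCN(S(=O)(=O)c3cccc(-c4ccc(F)cc4)c3)CC2)CC1` gives 12 nM. Among the compounds with values here, the only single-point step measured, a 6.0-fold lower number from compound 1 to compound 3 (0.78 log units; beyond the scatter), was modest. Compound 4 `CC1CCN(C2CCN(S(=O)(=O)c3cccc(N)c3)CC2)CC1` differs from compound 3 by amino in place of naphthalen-2-yl on an aromatic carbon. Within the data shown here, no measured step trades a large group for amino, so the direction rests on compound 1 and compound 3 alone: enlarging the group lowered the number, and the much greater loss of size in compound 4 is expected to raise it, probably beyond the scatter. The expected step is a 75-fold higher number from compound 3 to compound 4 (1.88 log units; beyond the scatter). Compound 4 is therefore estimated at 150 nM, within 30 nM to 1500 nM.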

Compound 4, half-maximal inhibitory concentration: 3400 nM
For compound 4 the middle estimate is 23-fold (1.36 log units) below the measured one; the whole stated range lies below it.
By their numbers in this assay, from the lowest: compounds 3 and 2 (each within the scatter of the next); then compound 1; then compound 4.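

Amino at this place costs far more than the swap between the two aryl groups suggested: in this assay the change gives a 1700-fold higher number from compound 3 to compound 4 (3.23 log units; beyond the scatter) and a 280-fold higher number from compound 1 to compound 4 (2.45 log units; beyond the scatter). Replacing the whole aryl group on the sulfonyl sulfur gives a 1200-fold higher number from compound 2 to compound 4 (3.07 log units; beyond the scatter), so a low number here does not depend on the second aromatic ring, which compound 2 lacks. Nothing available here accounts for the size of this loss. Still open, going by these compounds, is whether the amino group itself or the missing aryl bulk matters more; a methyl, a methoxy or an unsubstituted phenyl at this place would help separate the two.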